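The source may hold more compounds than are shown below. What is called first, only, known or untested is meant among the compounds shown, and "the series" means these compounds.

Working notes on the series. Compound 1 `COc1ccc(C(=O)/C=C/c2cc(-c3cc(OC)c(OC)c(OC)c3)n3nc(-c4ccccc4)cc3n2)cc1` gives 14600 nM in a functional assay on A549 cells (Homo sapiens) for antiproliferative activity, read by MTT assay, with a stated time of 24 h; on this read-out higher numbers stand for weaker inhibition and lower numbers for stronger inhibition. Among the three numbers in hand, compound 1 sits second highest; compound 2 `COc1ccc(/C=C/C(=O)c2cc(-c3ccc(OC)c(OC)c3)n3nc(-c4ccccc4)cc3n2)cc1` gives 19300 nM in this assay, and compound 3 `COc1ccc(-c2cc(/C=C/C(=O)c3ccc(OC)c(OC)c3)nc3cc(-c4ccccc4)nn23)cc1` gives 7400 nM, and both gaps to compound 1 lie within the scatter, so no ordering among them is claimed. Among the compounds with values here, no single-point step between measured compounds is available in this assay.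

Compound 4 `COc1cc(-c2cc(/C=C/C(=O)c3ccccc3)nc3cc(-c4ccccc4)nn23)cc(OC)c1OC` differs from compound 1 by hydrogen in place of methoxy on an aromatic carbon. With nothing in hand to anchor this change, the step from compound 1 to compound 4 is expected to be a 1.1-fold higher number from compound 1 to compound 4 (0.04 log units; within the scatter), no larger than the scatter. Compound 4 is therefore estimated at 16000 nM in this assay, within a range from 6000 nM to 42000 nM.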

Compound 4, half-maximal inhibitory concentration: 18200 nM
Compound 4: the middle estimate sits 1.1-fold (0.06 log units) below what was measured; low and high end bracket the measured number.
By their numbers in this assay, from the lowest: compounds 3, 1, 4 and 2 (each within the scatter of the next, the first and the last beyond it).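

Hydrogen in place of methoxy, which turns the (4-methoxyphenyl)carbonyl group into benzoyl, gives the first single-place step in the series: in this assay the step is a 1.2-fold higher number from compound 1 to compound 4 (0.10 log units; within the scatter). At this place, on an aromatic carbon para to a large group, the methoxy can therefore give way to hydrogen with the read-out staying within the scatter. Nothing in hand explains this result.

From the compounds shown here alone, it remains open whether an amine or a carboxylic acid at this place would give a step beyond the scatter. Going by these compounds, whether the same replacement behaves alike on the other aryl rings also remains open.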